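Cyclopropylmethyl in place of methyl on the shared core

The compounds below may be only part of what the source reports. "The series", "measured", "known", "first", "only" and "open" are said of these compounds alone.

Measured so far:
compound 1 `FC(F)(F)Cc1cnc2c(Cl)c(-c3cc(Cl)c4c(ccn4CC4CC4)c3)ccn12` 193%
compound 2 `N#Cc1c(-c2ccc3c(ccn3CC3CC3)c2)ccn2c(CC(F)(F)F)cnc12` 230%
compound 3 `Cn1ccc2cc(-c3ccn4c(CC(F)(F)F)cnc4c3C#N)cc(Cl)c21` 184%

In a functional assay on CHO cells for agonist activity at metabotropic glutamate receptor 2 (Homo sapiens) (a lower number here means a smaller maximal response, a higher number a larger maximal response), compound 3 stands lowest of the three numbers. Its nearest neighbour is compound 1, whose value lies within the usual scatter of that of compound 3, so no order between the two can be claimed. Compound 2 lies furthest away, beyond the scatter, above compound 3. Compounds 1, 2 and 3 each differ from one another in more than one place, so no single change among them can be read as a step.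

Compound 4 `N#Cc1c(-c2cc(Cl)c3c(ccn3CC3CC3)c2)ccn2c(CC(F)(F)F)cnc12` is not yet measured. It differs from compound 3 in one place: cyclopropyl in place of hydrogen on a saturated chain carbon bound to an aromatic nitrogen.

For the measured compounds named here, no measured pair isolates this change. Compounds 1 and 2 both carry the cyclopropylmethyl and both sit at or above compound 3, so a step upward beyond the scatter is expected from compound 3 to compound 4, of moderate size, estimated as a number 21 percentage points higher from compound 3 to compound 4 (beyond the scatter). For compound 4 the expected value in this assay is 205%, with a range from 175% to 240%.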

Compound 4, largest response reached (Emax), in percent of the reference or control that the assay uses: 200%
Compound 4: the middle estimate sits 5 percentage points above what was measured; measured number inside the range.
By their numbers in this assay, from the lowest: compounds 3, 1 and 4 (each within the scatter of the next, the first and the last beyond it); then compound 2.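

In this assay, cyclopropyl in place of hydrogen on a saturated chain carbon bound to an aromatic nitrogen can now be read as a single change, giving a number 16 percentage points higher from compound 3 to compound 4 (beyond the scatter) on a shared core that carries the chloro and the nitrile. Chloro in place of hydrogen on an aromatic carbon gives a number 30 percentage points lower from compound 2 to compound 4 (beyond the scatter) with the cyclopropylmethyl held constant, so the high response of compound 2 does not carry over to its chloro analogue. Cyano in place of chloro on an aromatic carbon gives a number 7 percentage points higher from compound 1 to compound 4 (within the scatter) and so does not separate these two groups at this place.

Going by these compounds, whether a longer chain or a cyclobutylmethyl group on that aromatic nitrogen would extend the step, and whether the step holds without the chloro, remains open. No measurement at hand explains any of these steps.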